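The compounds below may be only part of what the source reports. "The series", "measured", "known", "first", "only" and "open" are said of these compounds alone.

Measured compounds:
compound 1 `O=S(=O)(CC1=NCCO1)c1c(-c2ccc(Cl)cc2)nn(-c2ccccc2)c1-c1ccc(Cl)cc1`: "not active" (no number reported)
compound 2 `COc1ccc(C2=NN(c3ccccc3)C(c3ccc(C)cc3)C2S(=O)(=O)CC2=NCCS2)cc1`: 47.9%

In a functional assay, tested at 100 ug/mL (on this read-out lower numbers stand for a weaker effect and higher numbers for a stronger effect at the one concentration tested), compound 1 is reported as "not active" (no number reported), so no number stands behind it and its place cannot be fixed on a scale; it can only be taken as the weak end of what has been measured. In this assay compound 2 gives 47.9%, a clear effect at the one concentration tested. Within the data shown here, no step between these two is computed, because they differ in more than one place; the two values show only that one of the pair carries an effect and the other does not.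

Compound 3 `O=S(=O)(CC1=NCCS1)c1c(-c2ccc(Cl)cc2)nn(-c2ccccc2)c1-c1ccc(Cl)cc1` has not yet been measured. It differs from compound 1 by a group of 5 heavy atoms (3 carbon, 1 nitrogen, 1 sulfur; one five-membered non-aromatic ring with 2 hetero atoms) in place of a group of 5 heavy atoms (3 carbon, 1 nitrogen, 1 oxygen; one five-membered non-aromatic ring with 2 hetero atoms), on a saturated chain carbon bound to a sulfonyl sulfur. Among the measured compounds shown here, the same ring that enters here is also the ring carried by compound 2, which is the one measured compound with a reported effect. For the measured compounds named here, on this basis the step from compound 1 to compound 3 is expected to go upward in this assay, by an amount that may well exceed the usual scatter, though the data give no step of this kind to size it. Compound 3 is estimated to reach 22%, in a range from 0% to 50%.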

Compound 3, a percentage reported as activity, at one concentration (the size of the read-out at that concentration, not a potency): "not active" (no number reported)
No number was reported for compound 3; the estimate stays without a comparison.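

In this assay compound 1 is reported as "not active" (no number reported) and compound 3 as "not active" (no number reported), so no step can be read between them. No evidence at hand bears on this result. The compounds shown leave open whether this ring exchange can change the read-out at all, and which of its several differences from compound 3 goes with the effect of compound 2.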